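Replacing a Sulfonyl Group on the Ring Amine

This account rests on a few compounds, and the source may have more. Where it says the series, first, only, none or still open, it means among the compounds named here.

Compound 1 `Nc1nc(N2CCN(S(=O)(=O)c3ccccc3)CC2)c2nc(-c3ccc(F)cc3)sc2n1` is the anchor of this comparison. In a functional assay on cells (Lymphocyte, Homo sapiens) (a lower number here means a stronger inhibitor, a higher number a weaker inhibitor), compound 1 gives only a limit, > 10000 nM, so its standing is known as a limit and nothing more (the limit of > 10000 nM in this assay, at which 1 of the 2 values shown sits). Compound 2 `Nc1nc(N2CCN(C(=O)COc3ccc(Cl)cc3)CC2)c2nc(Cc3ccc(F)cc3)sc2n1` carries a different acyl group on the same ring nitrogen and a different link to its fluorophenyl ring; in this assay compound 2 gives 700 nM. The two differ in more than one place, so their values show only that one sits at a limit and the other at a measured number.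

Compound 3 `Nc1nc(N2CCN(C(=O)COc3ccccc3)CC2)c2nc(-c3ccc(F)cc3)sc2n1` has not yet been measured. Relative to compound 1 it differs in one place: (phenoxymethyl)carbonyl in place of phenylsulfonyl on an amine nitrogen in a ring. Within the data shown here, its acyl group resembles the one carried by compound 2, the only compound here with a number, 700 nM. The step expected in this assay is an at least 5.0-fold lower number from compound 1 to compound 3 (0.69 log units; beyond the scatter), a move toward stronger inhibition, beyond the usual scatter. Compound 3 is therefore estimated at 2000 nM, with a range from 400 nM to 10000 nM.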

Compound 3, half-maximal inhibitory concentration: 90 nM
For compound 3 the middle estimate is 22-fold (1.35 log units) above the measured one; the measured number lies below the stated range.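

Among these compounds, on the amine nitrogen in the ring, the exchange of phenylsulfonyl for (phenoxymethyl)carbonyl gives in this assay an at least 110-fold lower number from compound 1 to compound 3 (2.04 log units; beyond the scatter) and so provides the first step here that can be tied to one place. The earlier pair differed in more than one place, whereas here the rest of compound 1 stays the same, so this large step belongs to the exchange of these two groups alone, even though each carries one six-membered aromatic ring of carbon only and the same counts of hydrogen-bond donors and acceptors. The step is a minimum and not a measured size: the limit of > 10000 nM in this assay, at which 1 of the 3 values shown sits.

On these data alone, how a benzoyl or a simple acetyl group on this nitrogen would compare stays open, and with it the question of which part of the (phenoxymethyl)carbonyl group goes with the step. Also open, as far as these compounds go, is what a chlorine on the phenoxy ring or a carbon link to the fluorophenyl ring does on its own, for compound 2 carries both and differs from compound 3 in more than one place.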